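The compounds below may be only part of what the source reports. "The series", "measured", "known", "first", "only" and "open" are said of these compounds alone.

Compound 1, `COc1cc(/C=C/C(=O)C2=C(/C=C/c3ccc(O)c(OC)c3)NC(=O)NC2c2ccc(C)cc2)ccc1O`, gives 23.9% in a functional assay, with a stated time of 20 min, tested at 10 uM; a higher number here means a stronger effect of the compound at the concentration tested, a lower number a weaker effect.
Compound 2, `COc1cc(/C=C/C(=O)C2=C(/C=C/c3ccc(O)c(OC)c3)NC(=O)NC2c2ccc(O)cc2)ccc1O`, gives 72% in this assay.
Compound 3, `COc1cc(/C=C/C(=O)C2=C(/C=C/c3ccc(O)c(OC)c3)NC(=S)NC2c2ccccc2O)ccc1O`, gives 70.8% in this assay.

Among these three numbers, compound 3 stands second highest: its value sits within the scatter of compound 2, and well beyond the scatter above compound 1. Compound 4, `COc1cc(/C=C/C(=O)C2=C(/C=C/c3ccc(O)c(OC)c3)NC(=S)NC2c2c(Cl)cccc2Cl)ccc1O`, differs from compound 3 in a single place: 2,6-dichlorophenyl in place of 2-hydroxyphenyl on a saturated ring carbon. Going by the values given here, only one measured step touches that same position, a number 48.1 percentage points higher from compound 1 to compound 2 (beyond the scatter), and there the arrival of a hydroxy on the aryl group carried by the saturated ring carbon brought a large rise. Compound 4 goes the other way at this position, giving up the hydroxy for a group with no hydrogen-bond donor and no acceptor, much as compound 1 has none; the core of compound 3, however, is not the core of compound 1, so the analogy is loose. A drop beyond the scatter is nonetheless expected, and the estimated step is a number 32.8 percentage points lower from compound 3 to compound 4 (beyond the scatter). In this assay compound 4 is therefore estimated at 38%, most likely between 15% and 65%.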

Compound 4, a percentage reported as activity, at one concentration (the size of the read-out at that concentration, not a potency): 20.2%
For compound 4 the middle estimate is 17.8 percentage points above the measured one; the range from low to high includes it.
By their numbers in this assay, from the lowest: compounds 4 and 1 (each within the scatter of the next); then compounds 3 and 2 (each within the scatter of the next).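

In this assay the read-out is a number 50.6 percentage points lower from compound 3 to compound 4 (beyond the scatter), a large step, so the aryl group on the saturated ring carbon matters on the core of compound 3 as well as on the core of compound 1. In both steps measured at this position, the aryl group bearing a hydroxy goes with the higher number and no compound shown goes against this, although that rests on only two pairs. Nothing measured here gives a reason for the fall.

This change removes the hydroxy and brings in two chlorines in one move, so the share of each in the fall stays unresolved. Plain phenyl, 2-methoxyphenyl or 2-chlorophenyl on the same core would help to separate the two.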